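Bromo Substitution on Two Cores: Cytotoxicity in Rat Cells

The source may hold more compounds than are shown below. What is called first, only, known or untested is meant among the compounds shown, and "the series" means these compounds.

Compound 1 `CC(=O)OC[C@H]1O[C@@H](N2C(=O)/C(=C3/C(=O)Nc4ccccc43)c3ccccc32)[C@H](OC(C)=O)[C@@H](OC(C)=O)[C@@H]1OC(C)=O` is the starting point of this small set. In an ADME assay on L6 cells (Rattus norvegicus) for cytotoxicity, read by resazurin assay, with a stated time of 72 h (on this read-out lower numbers stand for stronger inhibition and higher numbers for weaker inhibition), compound 1 gives 4530 nM. Compound 2 `CC(=O)OC[C@H]1O[C@@H](N2C(=O)/C(=C3/C(=O)Nc4ccc(Br)cc43)c3ccccc32)[C@H](OC(C)=O)[C@@H](OC(C)=O)[C@@H]1OC(C)=O` carries bromo in place of hydrogen on an aromatic carbon; in this assay compound 2 gives 7700 nM, and the step of a 1.7-fold higher number from compound 1 to compound 2 (0.23 log units; within the scatter) is small. Compound 3 `CCCC(=O)c1ccc2c(c1)/C(=C1\C(=O)N([C@@H]3O[C@H](COC(C)=O)[C@@H](OC(C)=O)[C@H](OC(C)=O)[C@H]3OC(C)=O)c3ccccc31)C(=O)N2` has a different core, the change being (propylcarbonyl in place of hydrogen on an aromatic carbon); in this assay compound 3 gives 31700 nM, reached by the steps of a 7.0-fold higher number from compound 1 to compound 3 (0.84 log units; beyond the scatter) and a 4.1-fold higher number from compound 2 to compound 3 (0.61 log units; beyond the scatter).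

Compound 4 `CCCC(=O)c1ccc2c(c1)/C(=C1\C(=O)N([C@@H]3O[C@H](COC(C)=O)[C@@H](OC(C)=O)[C@H](OC(C)=O)[C@H]3OC(C)=O)c3ccc(Br)cc31)C(=O)N2` has not yet been measured in this assay. It differs from compound 3 by bromo in place of hydrogen on an aromatic carbon, which is the same change that separates compound 1 from compound 2, now made on the core of compound 3. Going by the values given here, the only evidence for the size of this change is the single step of a 1.7-fold higher number from compound 1 to compound 2 (0.23 log units; within the scatter), which stayed within the scatter. Among the compounds with values here, with that step as the only guide, a similarly small shift toward a higher number is expected for compound 4, and the expected step is a 1.6-fold higher number from compound 3 to compound 4 (0.20 log units; within the scatter). The estimate for compound 4 in this assay is 50000 nM, expected to fall between 20000 nM and 120000 nM.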

Compound 4, half-maximal inhibitory concentration: 99000 nM
For compound 4 the middle estimate is 2.0-fold (0.30 log units) below the measured one, and the stated range covers the measured number.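

In this assay, bromo in place of hydrogen on an aromatic carbon gives a 3.1-fold higher number from compound 3 to compound 4 (0.49 log units; beyond the scatter), a modest step toward weaker inhibition. Set beside the earlier step, this one does not differ from it by more than repeated measurements allow: the same change on two cores in this assay, a 1.7-fold higher number (0.23 log units; within the scatter) from compound 1 to compound 2 and a 3.1-fold higher number (0.49 log units; beyond the scatter) from compound 3 to compound 4, 1.8-fold (0.26 log units) apart, within the scatter of two such steps. The size of the change thus carried from the core of compound 1 to the core of compound 3 without a difference that can be told from scatter, but only the second step stands beyond the scatter by itself, and two cores cannot show that bromo raises the number on every core of this series, nor why the number rises.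

The compounds shown leave open whether chloro, methoxy or an amine in the same place would give a step like that of bromo. They also leave open whether the bromo step would keep its size if a carboxylic acid or a longer chain stood in place of the propylcarbonyl group.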